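The compounds below may be only part of what the source reports. "The series", "measured", "known", "first", "only" and "open" are said of these compounds alone.

The compounds measured so far:

In a functional assay on RAW264.7 cells (Mus musculus) for inhibition, read by fluorescence, with stated times of 1 h, 24 h and 30 min (a higher number here means a weaker inhibitor, a lower number a stronger inhibitor), compound 1 `O=C(/C=C/c1ccccc1C(F)(F)F)c1ccccc1` gives > 10000 nM, which is a limit of the assay rather than a number.
In this assay compound 2 `O=C(/C=C/c1ccccc1C(F)(F)F)c1ccc(O)cc1` gives > 10000 nM, again a limit and not a number.
In this assay compound 3 `O=C(/C=C/c1ccc(C(F)(F)F)cc1)c1ccccc1` gives > 10000 nM, also only a limit.

Compound 2 differs from compound 1 by hydroxy in place of hydrogen on an aromatic carbon. The step that the two limits leave unreadable from compound 1 to compound 2 cannot be sized, because the limit of > 10000 nM in this assay, at which 3 of the 3 values shown sit, leaves both ends open. Compound 3 has the same atoms as compound 1 joined differently; the difference between the two cores is not broken down here.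

Compound 4 `O=C(/C=C/c1ccc(C(F)(F)F)cc1)c1ccccc1O` has not yet been measured. It differs from compound 3 by hydroxy in place of hydrogen on an aromatic carbon. This is the same kind of change as from compound 1 to compound 2, not the same change: in compound 4 the hydroxy sits ortho to a large group, whereas in compound 2 it sits para to a large group.

For compound 4 a step that the limit leaves unreadable from compound 3 to compound 4 is expected, and this rests only on compound 1, compound 2 and compound 3 all sitting at the limit of > 10000 nM in this assay, at which 3 of the 3 values shown sit, which gives no readable direction. Compound 4 is accordingly estimated at 15000 nM, between 3000 nM and 60000 nM.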

Compound 4, half-maximal inhibitory concentration: > 10000 nM
Compound 4: a limit, no number; the forecaster's own chance of this, stated with the estimate: 70%; the middle value is on the limit's open side.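

In this assay compound 4 gives > 10000 nM as a limit and not a number. Going by these compounds alone, no step from compound 3 to compound 4 can be read, because both ends are open: the limit of > 10000 nM in this assay, at which 4 of the 4 values shown sit. The compounds shown leave open how strongly any of them inhibits, and whether adding a hydroxy changes that at all.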